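Ester Size and Growth Inhibition in Alkynyl Enol Ether Diesters

A few compounds are considered here, and "the series" means these few. Any claim that something is new, unique, unknown or untested is made for them only; others in the source may bear on it.

Measured compounds:
compound 1 `CCOC(=O)C#CC(O/C=C/C(=O)OCC)C(C)C` gives 2800 nM
compound 2 `CCC(C#CC(=O)OC)O/C=C/C(=O)OC` gives 540 nM
compound 3 `CCCC(C#CC(=O)OC)O/C=C/C(=O)OC` gives 320 nM

These three compounds were tested in a functional assay on SW1573 cells (Homo sapiens) for antiproliferative activity, read by sulforhodamine B assay, with a stated time of 48 h; a lower number here means a stronger inhibitor of growth, a higher number a weaker inhibitor of growth. Compound 1 has the highest number of the three. Compound 3 and compound 2 share a core; from compound 3 to compound 2 the change is hydrogen in place of methyl on a saturated chain carbon, three bonds along the chain from an oxygen on an unsaturated carbon and a triple-bonded carbon, and the step is a 1.7-fold higher number from compound 3 to compound 2 (0.23 log units; within the scatter). The difference between the core of compound 1 and the core of compound 3 is not broken down here.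

Compound 4 `CCOC(=O)C#CC(O/C=C/C(=O)OC)C(C)C` has not yet been measured. From compound 1 to compound 4 the change is hydrogen in place of methyl on a saturated chain carbon bound to an oxygen next to a carbonyl group. This is the same kind of change as from compound 3 to compound 2, but at a different place: there it sat three bonds along the chain from an oxygen on an unsaturated carbon and a triple-bonded carbon, here on a saturated chain carbon bound to an oxygen next to a carbonyl group. In this assay the earlier step was within the scatter, so a small step is expected here too, estimated as a 1.4-fold lower number from compound 1 to compound 4 (0.15 log units; within the scatter). Compound 4 is therefore expected to give about 2000 nM, likely between 800 nM and 5000 nM.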

Compound 4, concentration for 50% growth inhibition: 960 nM
Compound 4: the middle estimate sits 2.1-fold (0.32 log units) above what was measured; the measured number falls inside the stated range.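

In this assay, replacing ethoxy with methoxy gives a 2.9-fold lower number from compound 1 to compound 4 (0.46 log units; beyond the scatter). The same exchange of methyl for hydrogen, made at a different place on another core, does not give the same result: the same change on two cores in this assay, a 1.7-fold higher number (0.23 log units; within the scatter) from compound 3 to compound 2 and a 2.9-fold lower number (0.46 log units; beyond the scatter) from compound 1 to compound 4, 4.9-fold (0.69 log units) apart, beyond the scatter of two such steps. So a step seen on one core cannot simply be carried over to the other in this series, though with a single pair on each core, these data do not show why the two steps differ or what a third core would do.

The compounds shown leave open how a longer chain on the ester, or a carboxylic acid in its place, would behave on either core. They also leave open what changing the remaining ethoxycarbonyl of compound 4 to methoxycarbonyl would do.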